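The source may report more compounds than this note shows. Statements on the series, on what has been measured and on what is new or still open speak of the compounds shown alone.

Measured in a functional assay on RAW264.7 cells (Mus musculus) for inhibition, read by ELISA, with stated times of 30 min and 24 h; on this read-out higher numbers stand for weaker inhibition and lower numbers for stronger inhibition:

- Compound 1 `C[C@@H](CC[C@@H]1[C@@]2(C)CCCC(C)(C)[C@@H]2CC[C@@]1(C)O)CC(=O)O`: > 50000 nM
- Compound 2 `C[C@H](CCOC(=O)c1ccc(Br)cc1)CC[C@@H]1[C@@]2(C)CCCC(C)(C)[C@@H]2CC[C@@]1(C)O`: > 50000 nM

Neither compound gives a numerical half-maximal inhibitory concentration in this assay. For compound 2, the reading of > 50000 nM is a limit of the assay and not a number. Compound 1 likewise returns a limit, > 50000 nM. Compound 2 therefore stands at the limit of > 50000 nM in this assay, at which 2 of the 2 values shown sit.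

The next compound to be tested is compound 3 `CCCCCCCCCCCC(=O)OCC[C@@H](C)CC[C@@H]1[C@@]2(C)CCCC(C)(C)[C@@H]2CC[C@@]1(C)O`, an ester like compound 2. The change is undecyl in place of 4-bromophenyl on a carbonyl carbon. Among the measured compounds shown here, no pair of measured compounds shows what a change at this place does, and no measured number exists from which to gauge one. Any expectation must therefore start from the limit itself, and no step beyond the usual scatter is foreseen in this assay, in either direction. The expected change is a number no higher from compound 2 to compound 3 (the limit leaves the size open). It would not be surprising if the assay again reported only a limit. The estimated value for compound 3 is 50000 nM, with an expected range from 20000 nM to 100000 nM.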

Compound 3, half-maximal inhibitory concentration: > 50000 nM
Compound 3 gave a limit, no number; the forecaster's own chance of this, stated with the estimate: 70%; the middle value lies on the limit itself.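

In this assay compound 3, like compound 2, returns only a limit of the assay and not a number, so no step can be read for undecyl in place of 4-bromophenyl: the limit of > 50000 nM in this assay, at which 3 of the 3 values shown sit.

The compounds shown leave open which change, if any, would bring a numerical half-maximal inhibitory concentration within reach of this assay.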